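Two Chlorines on the Amide Phenyl of a Dopamine Agonist

The compounds below may be only part of what the source reports. "The series", "measured", "known", "first", "only" and "open" are said of these compounds alone.

Of the compounds shown here, three sharing one core have been measured in a functional assay on HEK293 cells for agonist activity at D(4) dopamine receptor (Homo sapiens), read by FLIPR; a higher number here means that more compound is needed for the effect, a lower number that less compound is needed. Compound 1 `O=C(CN1CCC(c2cccc[n+]2[O-])CC1)Nc1cccc(Cl)c1` gives 62 nM, compound 2 `Cc1cc(F)ccc1NC(=O)CN1CCC(c2cccc[n+]2[O-])CC1` gives 60 nM, and compound 3 `O=C(CN1CCC(c2cccc[n+]2[O-])CC1)Nc1cccc(F)c1` gives 160 nM, the highest of the three numbers; the nearest to it is compound 1, with a 2.6-fold higher number from compound 1 to compound 3 (0.41 log units; beyond the scatter). Compound 4 `O=C(CN1CCC(c2cccc[n+]2[O-])CC1)Nc1cc(Cl)cc(Cl)c1` has not yet been measured. It differs from compound 3 by 3,5-dichlorophenyl in place of 3-fluorophenyl on an amide-type nitrogen. The step that bears most on this change is a 2.6-fold higher number from compound 1 to compound 3 (0.41 log units; beyond the scatter), in which a chloro in place of a fluoro gave the lower number; compound 4 carries two chlorines. A lower number for compound 4 is therefore expected, roughly a 3.6-fold lower number from compound 3 to compound 4 (0.55 log units; beyond the scatter), giving an estimated 45 nM with a range from 15 nM to 150 nM.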

Compound 4, half-maximal effective concentration: 160 nM
Compound 4: the middle estimate sits 3.6-fold (0.55 log units) below what was measured; the whole stated range lies below it.
By their numbers in this assay, from the lowest: compounds 2 and 1 (each within the scatter of the next); then compounds 3 and 4 (each within the scatter of the next).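

A second chlorine on the amide phenyl gives a 2.6-fold higher number from compound 1 to compound 4 (0.41 log units; beyond the scatter), so at this position more chlorine does not go with a lower number. Placing 3,5-dichlorophenyl on the amide-type nitrogen gives no change at the digits printed from compound 3 to compound 4 (within the scatter), while the same group in place of 4-fluoro-2-methylphenyl gives a 2.7-fold higher number from compound 2 to compound 4 (0.43 log units; beyond the scatter), so the gain from chloro over fluoro does not carry over to the dichloro group. Nothing measured here explains this result.

Still open, from the compounds shown here alone, is how a methoxy group, an amine or a carboxylic acid on this phenyl would change the number. A single bromine in place of the chlorine also remains to be compared.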